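This account rests on a few compounds, and the source may have more. Where it says the series, first, only, none or still open, it means among the compounds named here.

Measured compounds:
- compound 2 `Cn1sc2cc(OCc3cccc(-c4ccc(Cl)c(C(=O)O)c4)c3)ccc2c1=O`: 100%
- compound 3 `O=C(O)c1cc(-c2cccc(COc3ccc4c(=O)n(CC5CC5)sc4c3)c2)ccc1Cl`: 100%
- compound 1 `O=C1c2ccc(OCc3cccc(-c4ccc(Cl)cc4F)c3)cc2CN1C1CCCC1`: "not determined" (no result reported)

In an ADME assay on a cell-free system (plasma, Rattus norvegicus) for metabolic stability, read by LC-MS, with a stated time of 1 h, at 37 degrees C, tested at 100 uM (on this read-out lower numbers stand for a less stable compound and higher numbers for a more stable compound), compound 2 gives 100% and compound 3 gives 100%. For the measured compounds named here, the step of no change at the digits printed from compound 2 to compound 3 (within the scatter) is the only measured step, and it lies within the scatter. Going by the values given here, compound 1 stands with no number of its own in this assay, so there is no starting value to step from.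

Compound 4 `O=C1c2ccc(OCc3cccc(-c4ccccc4)c3)cc2CN1C1CCCC1` differs from compound 1 in one place: phenyl in place of 4-chloro-2-fluorophenyl on an aromatic carbon. Among the compounds with values here, no measured step touches this kind of change; the one known step concerns a saturated chain carbon bound to an aromatic nitrogen on a different core, and it showed no change beyond the scatter. The two measured compounds, which share neither core nor exchanged group with compound 4, both sit at the top of the read-out in this assay.

Within the data shown here, for compound 4 the expected result in this assay is 95%, within a range of 80% to 100%, with no direction of step claimed because compound 1 has no value.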

Compound 4, percent of the compound remaining: 95%
For compound 4 middle estimate and measured number coincide at the digits printed; measured number inside the range.
By their numbers in this assay, from the lowest: compounds 4, 2 and 3 (each within the scatter of the next).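

No new step can be read, since compound 1 has no number to set against compound 4. On these data alone, whether exchanging 4-chloro-2-fluorophenyl for phenyl shifts this read-out at all stays open. Nothing measured here offers an explanation for the result of compound 4.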